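The source may hold more compounds than are shown below. What is called first, only, known or untested is meant among the compounds shown, and "the series" means these compounds.

Measured so far, in a functional assay on the whole organism for inhibition, with Echinochloa esculenta as the target; a higher number here means a weaker inhibitor, a lower number a stronger inhibitor:
- compound 1 `Fc1cc(Cl)ccc1-n1c(=S)n2n(c1=S)CCCC2`: 91.2 nM
- compound 2 `COC(=O)CSc1cc(-n2c(=S)n3n(c2=S)CCCC3)c(F)cc1Cl`: 195 nM
- compound 3 `Fc1cc(Cl)ccc1/N=c1\sc(=S)n2n1CCCC2`: 158 nM

Compound 2 is compound 1 with ((methoxycarbonyl)methyl)sulfanyl in place of hydrogen on an aromatic carbon; the result is a 2.1-fold higher number from compound 1 to compound 2 (0.33 log units; beyond the scatter). Compound 3 carries the same atoms as compound 1 joined differently; the difference between the two cores is not broken down here. Compound 3 and compound 2 sit within the scatter of each other in this assay, as do compound 3 and compound 1.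

Compound 4 `COC(=O)CSc1cc(/N=c2\sc(=S)n3n2CCCC3)c(F)cc1Cl`, not yet measured, is compound 3 with ((methoxycarbonyl)methyl)sulfanyl in place of hydrogen on an aromatic carbon, the same change as that between compound 1 and compound 2, at a place described in identical words. The expected step is therefore a 2.1-fold higher number from compound 3 to compound 4 (0.32 log units; beyond the scatter), resting on the measured 2.1-fold higher number from compound 1 to compound 2 (0.33 log units; beyond the scatter). Compound 4 is estimated at 330 nM in this assay, most likely between 170 nM and 650 nM.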

Compound 4, half-maximal inhibitory concentration: 269 nM
Compound 4: middle estimate off by 1.2-fold (0.09 log units), on the high side; the measured number falls inside the stated range.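

In this assay, ((methoxycarbonyl)methyl)sulfanyl in place of hydrogen on an aromatic carbon gives a 1.7-fold higher number from compound 3 to compound 4 (0.23 log units; within the scatter), a step that stays within the scatter on this core. For the compounds shown here, with only one pair per core in this one assay, the result does not show that the change would carry over to any other core, and it does not explain why the numbers move. On these two cores, the change carries over without a difference that can be told from the scatter: the same change on two cores in this assay, a 2.1-fold higher number (0.33 log units; beyond the scatter) from compound 1 to compound 2 and a 1.7-fold higher number (0.23 log units; within the scatter) from compound 3 to compound 4, 1.3-fold (0.10 log units) apart, within the scatter of two such steps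

Only this one group is shown at this place on the ring. From the compounds shown here alone, a carboxylic acid in place of the methyl ester, a longer chain on the sulfur, or an amine at the same carbon remains open on both cores.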